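A few compounds are considered here, and "the series" means these few. Any claim that something is new, unique, unknown or untested is made for them only; others in the source may bear on it.

Measured in a functional assay on HepG2 cells (Homo sapiens) for inhibition, read by MTT assay, with a stated time of 72 h; a lower number here means a stronger inhibitor, a higher number a weaker inhibitor:
- Compound 1 `CC(C)(C)n1cc2c(n1)C(=O)CC1(CCN(C(=O)c3cc(-c4ccc(Cl)cc4)nc4ccccc34)CC1)O2`: 630 nM
- Compound 2 `CC(C)(C)n1cc2c(n1)C(=O)CC1(CCN(C(=O)c3cc(-c4ccncc4)nc4ccccc34)CC1)O2`: 380 nM

These two numbers cannot be ranked. For the measured compounds named here, the only measured step between them is a 1.7-fold lower number from compound 1 to compound 2 (0.22 log units; within the scatter), and compound 2 therefore stands level with its sole neighbour. Compound 3 `Cc1cc(C(=O)N2CCC3(CC2)CC(=O)c2nn(C(C)(C)C)cc2O3)c2ccccc2n1` departs from compound 2 at that same place, next to the ring nitrogen, with methyl in place of pyridin-4-yl on an aromatic carbon. The measured step bears on this only loosely, since it swapped one six-membered aromatic ring for another, whereas here the ring is lost. Going by the values given here, no measured compound lacks that ring. Going by these compounds, a small move towards a higher number is therefore expected, though the opposite direction remains open. The estimated step is a 1.8-fold higher number from compound 2 to compound 3 (0.27 log units; within the scatter). In this assay, compound 3 is estimated at 700 nM, with an expected range from 200 nM to 2500 nM.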

Compound 3, half-maximal inhibitory concentration: 9480 nM
Compound 3: middle estimate off by 14-fold (1.13 log units), on the low side; measured number above the stated range.
By their numbers in this assay, from the lowest: compounds 2 and 1 (each within the scatter of the next); then compound 3.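

In this assay, the group on this aromatic carbon, next to the ring nitrogen, proves far from interchangeable: methyl in place of pyridin-4-yl gives a 25-fold higher number from compound 2 to compound 3 (1.40 log units; beyond the scatter) and methyl in place of 4-chlorophenyl gives a 15-fold higher number from compound 1 to compound 3 (1.18 log units; beyond the scatter) in the same direction. The exchange of one six-membered aromatic ring for the other had stayed within the scatter, so only the loss of the ring reveals how much this position can move the number. No evidence at hand accounts for the size of this rise.

Going by these compounds, what remains open is whether an aromatic ring is needed here as such, or whether a larger group of another kind would serve as well. A cyclohexyl ring or a longer chain such as n-butyl on this carbon would address that question.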